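The source may report more compounds than this note shows. Statements on the series, on what has been measured and on what is new or still open speak of the compounds shown alone.

Measured compounds:
Compound 1, `COc1ccc(C(=O)C2=C(O)C(=O)N(c3ccc(-c4ccon4)cc3)C2c2ccccc2OC)cc1`: 0.5 h
Compound 2, `COc1ccc(C(=O)C2=C(O)C(=O)N(c3ccc(-c4ccon4)cc3)C2c2ccccc2OCCO)cc1`: 0.5 h
Compound 3, `COc1ccccc1C1C(C(=O)C(C)C)=C(O)C(=O)N1c1ccc(-c2ccsc2)cc1`: 6.1 h

In an ADME assay on the whole organism (Rattus norvegicus) for metabolic stability (a higher number here means that the compound lasts longer, a lower number that the compound disappears faster), compound 1 gives 0.5 h and compound 2 gives 0.5 h. The change between them, (hydroxymethyl in place of hydrogen on a saturated chain carbon bound to an oxygen on an aromatic ring), gave no change at the digits printed from compound 1 to compound 2 (within the scatter). Compound 3 gives 6.1 h in this assay; how its core differs from the core of compound 1 is not broken down here.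

Compound 4, `CC(C)C(=O)C1=C(O)C(=O)N(c2ccc(-c3ccsc3)cc2)C1c1ccccc1OCCO`, has not been measured. It differs from compound 3 by hydroxymethyl in place of hydrogen on a saturated chain carbon bound to an oxygen on an aromatic ring, the same change that was made from compound 1 to compound 2, and it occurs twice among these compounds. Since that earlier change gave no change at the digits printed from compound 1 to compound 2 (within the scatter), the step of a 1.0-fold lower number from compound 3 to compound 4 (0.01 log units; within the scatter) is also expected to stay within the scatter. Compound 4 is therefore estimated to give 6 h in this assay, with a range from 3 h to 12 h.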

Compound 4, half-life: 1 h
For compound 4 the middle estimate is 6.0-fold (0.78 log units) above the measured one, outside the stated range (below it).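

In this assay the change from 2-methoxyphenyl to 2-(2-hydroxyethoxy)phenyl gave a 6.1-fold lower number from compound 3 to compound 4 (0.79 log units; beyond the scatter), so a result for this change on one core did not carry over to the other. The two steps differ: the same change on two cores in this assay, no change at the digits printed (within the scatter) from compound 1 to compound 2 and a 6.1-fold lower number (0.79 log units; beyond the scatter) from compound 3 to compound 4, 6.1-fold (0.79 log units) apart, beyond the scatter of two such steps. This shows that the effect of the change depends on the core in at least this one pair of cores, but it does not show which of the differences between the cores is responsible, nor how the change would behave on any further core.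

The compounds shown leave open whether a longer chain or an amine in place of the 2-hydroxyethoxy group would also differ between the two cores.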